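The compounds below may be only part of what the source reports. "The series", "measured", "known", "first", "only" and "open" are said of these compounds alone.

For the measured compounds named here, compound 3, whose structure is `COc1ncc(-c2ccccc2)cc1[C@@H](c1ccccc1)[C@@](O)(CCN(C)C)c1cc(F)cc(F)c1`, is the one member of this series with a reported number. Compound 3 gives 28.8 ug/mL in a toxicity assay on HeLa cells (Homo sapiens) for cytotoxicity; on this read-out lower numbers stand for higher toxicity in this test and higher numbers for lower toxicity in this test. Two related compounds carry no result: compound 1 with structure `COc1nc(-c2cccc(Cl)c2)ccc1[C@@H](c1ccccc1)[C@@](O)(CCN(C)C)c1cccc2ccccc12`, which in this assay shows "nd" (no result reported), and compound 2 with structure `COc1ncc(-c2ccccc2)cc1[C@@H](c1ccccc1)[C@@](O)(CCN(C)C)c1cc(F)ccc1F`, which in this assay shows "nd" (no result reported), so compound 3 stands alone and cannot be ranked against them. The next compound, compound 4 with structure `COc1ncc(-c2ccccc2)cc1[C@@H](c1ccccc1)[C@@](O)(CCN(C)C)c1ccccc1`, differs from compound 3 in one place: phenyl in place of 3,5-difluorophenyl on a saturated chain carbon bound to an oxygen on a saturated carbon and two saturated chain carbons. Going by the values given here, with no pair of measured compounds to show how such a change moves this read-out, the size of the step rests on the change alone; a swap of a 3,5-difluorophenyl for a phenyl on a saturated chain carbon is a small one, and compound 4 is expected to stay within the usual scatter of compound 3, with at most a slight drift toward a higher number, as the expected step of a 1.2-fold higher number from compound 3 to compound 4 (0.08 log units; within the scatter) states. Compound 4 is therefore estimated at 35 ug/mL in this assay, with a range from 15 ug/mL to 70 ug/mL.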

Compound 4, half-maximal cytotoxic concentration: 11.9 ug/mL
Compound 4: the middle estimate sits 2.9-fold (0.47 log units) above what was measured; the whole stated range lies above it.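

For the compounds shown here, the first readable step falls at the aryl group on the saturated chain carbon bound to an oxygen: in this assay, phenyl in place of 3,5-difluorophenyl gives a 2.4-fold lower number from compound 3 to compound 4 (0.38 log units; beyond the scatter). This shows that the position is not silent on this read-out, and that losing the fluorines here moves the number towards higher toxicity in this test, not lower. Nothing at hand speaks to why the number moves.

This single pair leaves open whether one fluorine on the phenyl would give a number between the two, and whether the shift belongs to fluorine specifically. On these data alone, how a chlorine, a methoxy group or a nitrile at the same place would read in this assay also remains open.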